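The compounds below may be only part of what the source reports. "The series", "measured", "known", "first", "only" and "open" are said of these compounds alone.

Compound 1 `CCCCNc1cc(C)nc2c(-c3ccc(Cl)cc3Cl)nn(C)c12` and compound 2 `CCCCCN(CCCC)c1cc(C)nc2c(-c3ccc(Cl)cc3Cl)nn(C)c12` share one core and differ only in what sits on a nitrogen on an aromatic ring. In an assay on HEK293 cells for displacement of a labelled ligand from corticotropin-releasing factor receptor 1 (Homo sapiens) (a higher number here means a weaker inhibitor, a lower number a stronger inhibitor), compound 1 gives 170 nM, and in this assay compound 2 gives 0.9 nM. For the measured compounds named here, the single measured step, a 190-fold lower number from compound 1 to compound 2 (2.28 log units; beyond the scatter), comes with pentyl in place of hydrogen on that nitrogen. Among the two numbers known so far, compound 2 holds the lowest, with compound 1 as its only neighbour.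

Compound 3 `CCCCN(c1cc(C)nc2c(-c3ccc(Cl)cc3Cl)nn(C)c12)C(CC)CC` is the unmeasured partner of compound 2; the two have the same atoms, joined differently, the difference being (pentan-3-yl in place of pentyl on a nitrogen on an aromatic ring). The measured step from compound 1 to compound 2 concerns adding a chain where there was none, so it bears only loosely on rearranging a chain that is already present. With nothing shown about such a rearrangement, no step beyond the scatter is expected, and the estimated step is a 1.7-fold higher number from compound 2 to compound 3 (0.22 log units; within the scatter). For compound 3 in this assay the expected value is therefore 1.5 nM, with a range from 0.4 nM to 6 nM.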

Compound 3, inhibition constant: 7 nM
Compound 3: the middle estimate sits 4.7-fold (0.67 log units) below what was measured; measured number above the stated range.
By their numbers in this assay, from the lowest: compound 2; then compound 3; then compound 1.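

Compound 3 shows that at this nitrogen on an aromatic ring, it is not enough to know that a second chain is present or how many carbons it holds. Pentyl and pentan-3-yl each have 5 carbon atoms and differ only in how those atoms are joined, yet in this assay that rearrangement alone gives a 7.8-fold higher number from compound 2 to compound 3 (0.89 log units; beyond the scatter). The branched chain still retains much of the gain from filling this place, with a 24-fold lower number from compound 1 to compound 3 (1.39 log units; beyond the scatter), so pentan-3-yl in place of hydrogen is also a large step, though a smaller one than pentyl gives. Nothing measured alongside these numbers bears on why the two chains differ.

With pentan-3-yl as the only branched chain shown, it remains open whether this higher number belongs to branching in general or to this one group. An isopropyl group, a longer straight chain such as hexyl, or a ring such as cyclopentyl on the same nitrogen would help separate those possibilities.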